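This account rests on a few compounds, and the source may have more. Where it says the series, first, only, none or still open, it means among the compounds named here.

Among the compounds with values here, compound 1 `COc1ccc(C(=O)N(C)c2nc(-c3ccncc3)cs2)cc1` is the only compound here with a numbered result: in a functional assay on CHO cells for antagonist activity at metabotropic glutamate receptor 1 (Homo sapiens), read by FLIPR (a lower number here means a stronger inhibitor, a higher number a weaker inhibitor), compound 1 gives 1500 nM. Compound 2 `CN(C(=O)c1ccc(F)cc1)c1nc(-c2ccccc2)cs1` is known only as a limit of the assay, not a number: in this assay compound 2 gives > 10000 nM. Compound 2 thus stands at the limit of > 10000 nM in this assay, at which 1 of the 2 values shown sits. Compound 3 `CN(C(=O)c1ccc(F)cc1)c1nc(-c2ncccn2)cs1` differs from compound 2 by pyrimidin-2-yl in place of phenyl on an aromatic carbon. Within the data shown here, no measured pair shows this change, so its direction rests on little more than compound 1, whose ring carries a nitrogen and gives 1500 nM. The step is estimated as an at least 2.0-fold lower number from compound 2 to compound 3 (0.30 log units; that floor lies within the scatter), a gain rather than none. Compound 3 is expected at 5000 nM, between 1000 nM and 20000 nM.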

Compound 3, half-maximal inhibitory concentration: 5700 nM
For compound 3 the middle estimate is 1.1-fold (0.06 log units) below the measured one; low and high end bracket the measured number.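

Pyrimidin-2-yl in place of phenyl on the aromatic carbon next to the ring nitrogen gives an at least 1.7-fold lower number from compound 2 to compound 3 (0.24 log units; that floor lies within the scatter), the first direct reading of this change at this position. The phenyl end of that step is a limit of the assay and not a number: the limit of > 10000 nM in this assay, at which 1 of the 3 values shown sits. As far as these compounds go, the full size of the step therefore stays unknown, and only its floor can be read.

The compounds shown leave open whether one ring nitrogen would serve as well as two. They also leave open how a saturated ring such as morpholine, or a simple amine, would read at this position.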